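The source may report more compounds than this note shows. Statements on the series, on what has been measured and on what is new or still open speak of the compounds shown alone.

In an ADME assay on HEK293 cells (Homo sapiens) for cytotoxicity, read by luminescence, with a stated time of 72 h (a lower number here means that less compound is needed, a higher number that more compound is needed for the effect), three compounds sharing one core have been measured so far. Compound 2 `CCOC(=O)c1c(-c2cccc(-c3ccccc3)c2)[nH]c2cc(OC(C)C)ccc2c1=O` gives > 22000 nM, which is a limit of the assay and not a number. Compound 1 `CCOC(=O)c1c(-c2cccc(Cl)c2)[nH]c2cc(OC)ccc2c1=O` gives > 22000 nM, also a limit. Compound 3 `CCOC(=O)c1c(-c2cccc(OC)c2)[nH]c2cc(OC(C)C)ccc2c1=O` gives > 22000 nM, again a limit. Compound 2 therefore stands with the others, and the data show this as the limit of > 22000 nM in this assay, at which 3 of the 3 values shown sit.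

Compound 4 `CCOC(=O)c1c(-c2cccc(-c3ccccc3)c2)[nH]c2cc(Cl)ccc2c1=O` departs from compound 2 by a single change: chloro in place of isopropoxy on an aromatic carbon. In words, this is chloro in place of isopropoxy on an aromatic carbon. Going by the values given here, the one measured step that bears on it is a step that the two limits leave unreadable from compound 2 to compound 3, and it concerns a different change, methoxy in place of phenyl. It offers no size to carry over, so no step beyond the scatter is expected. The expected change is a number no higher from compound 2 to compound 4 (the limit leaves the size open), an estimate that assumes no clear shift. For compound 4 the estimated value is 22000 nM, with an expected range from 10000 nM to 30000 nM. The most likely outcome is another limit rather than a number.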

Compound 4, half-maximal effective concentration: > 22000 nM
Compound 4: no number, only a limit; the forecaster's own chance of this, stated with the estimate: 80%; the middle value sits exactly at the limit.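

Compound 2 and compound 4 each give a limit and not a number, so the step between them cannot be read in this assay. The compounds shown leave open whether any change on the shared core shifts this read-out at all, as every value so far is the same limit: the limit of > 22000 nM in this assay, at which 4 of the 4 values shown sit.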